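The compounds below may be only part of what the source reports. "The series", "measured", "known", "first", "only" and "open" are said of these compounds alone.

Values in a functional assay on HT-29 cells (Homo sapiens) for antiproliferative activity, read by MTT assay, with a stated time of 72 h (on this read-out higher numbers stand for weaker inhibition and lower numbers for stronger inhibition), follow.
Compound 1 (`Cn1ncnc1-c1cc(Oc2ccc(NC(=O)Nc3cccc(C(F)(F)F)c3)cc2F)ccn1`) gives > 50000 nM as a limit.
Compound 2 (`Cn1cnnc1-c1cc(Oc2ccc(NC(=O)Nc3cccc(C(F)(F)F)c3)cc2F)ccn1`) gives 3020 nM as a number.
Compound 3 (`CN(C)CCn1cnnc1-c1cc(Oc2ccc(NC(=O)Nc3ccc(Cl)c(C(F)(F)F)c3)cc2F)ccn1`) gives 880 nM as a number.

Compound 2 holds the higher of the two actual numbers, and compound 3 lies lower, beyond the scatter. The next entry is compound 4 (`CN(C)CCn1cnnc1-c1cc(Oc2ccc(NC(=O)Nc3cccc(C(F)(F)F)c3)cc2F)ccn1`). Its difference from compound 2 ((dimethylamino)methyl in place of hydrogen on a saturated chain carbon bound to an aromatic nitrogen) is (dimethylamino)methyl in place of hydrogen on a saturated chain carbon bound to an aromatic nitrogen. Within the data shown here, the one measured step (an at least 16-fold lower number from compound 1 to compound 2 (1.21 log units; beyond the scatter)) is large but concerns a different change, so it bears only loosely. Compound 3 at 880 nM stands closer, carrying the same 2-(dimethylamino)ethyl chain, though also a chlorine absent from compound 4. The expected change in this assay is a modest fall in the number (a 2.0-fold lower number from compound 2 to compound 4 (0.30 log units; within the scatter)). For compound 4 the estimated value is 1500 nM with an expected range from 500 nM to 5000 nM in this assay.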

Compound 4, half-maximal inhibitory concentration: 1470 nM
Compound 4: the middle estimate sits 1.0-fold (0.01 log units) above what was measured; the range from low to high includes it.
By their numbers in this assay, from the lowest: compounds 3 and 4 (each within the scatter of the next); then compound 2. At a limit, above all of these: compound 1.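

Among these compounds, replacing methyl by 2-(dimethylamino)ethyl gives the first reading at this place, on a saturated chain carbon bound to an aromatic nitrogen, in this assay: a 2.1-fold lower number from compound 2 to compound 4 (0.31 log units; beyond the scatter) is a modest step, only just past the scatter. With this chain in place, hydrogen in place of chloro gives a 1.7-fold higher number from compound 3 to compound 4 (0.22 log units; within the scatter) and so separates compound 3 and compound 4 by no real margin. Compound 1 is a limit, so an at least 34-fold lower number from compound 1 to compound 4 (1.53 log units; beyond the scatter) is only a bound: the limit of > 50000 nM in this assay, at which 1 of the 4 values shown sits.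

From the compounds shown here alone, whether the terminal dimethylamino group matters, or the chain alone, stays open. So does the effect of a morpholine or a carboxylic acid at the chain end, or of a longer chain.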